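Hydroxamate series: amide cap change from compound 3 to compound 4

The source may report more compounds than this note shows. Statements on the series, on what has been measured and on what is new or still open speak of the compounds shown alone.

Three compounds carry the same hydroxamic acid chain and differ at the cap and the amide. Compound 1 `O=C(CCCCC[C@H](NC(=O)c1cc2c(O)cccc2[nH]1)C(=O)NCc1ccccc1)NO` gives 2210 nM in a functional assay on NFF cells (Homo sapiens) for antiproliferative activity; a higher number here means a weaker inhibitor, a lower number a stronger inhibitor. Compound 2 `CN(C)c1ccc(NC(=O)[C@H](CCCCCC(=O)NO)NC(=O)/C=C/c2ccccc2)cc1` gives 240 nM in this assay. Compound 3 `O=C(CCCCC[C@H](NC(=O)OCc1ccccc1)C(=O)NCc1ccncc1)NO` gives 23300 nM in this assay and is the weakest of the three, standing beyond the scatter from both compound 1 and compound 2.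

Compound 4 `O=C(CCCCC[C@H](NC(=O)OCc1ccccc1)C(=O)Nc1cccc2cccnc12)NO` has not yet been measured. It differs from compound 3 in one place: quinolin-8-yl in place of (pyridin-4-yl)methyl on an amide-type nitrogen. The cap of compound 3 is kept unchanged.

For the measured compounds named here, no measured pair shows this change on its own, so its size cannot be read from the numbers at hand. The two aryl amides in the set, compound 2 with 240 nM and compound 3 with 23300 nM, sit far apart, but they also differ in the group on the other amide nitrogen. The step from compound 3 to compound 4 is expected to be a 4.7-fold lower number from compound 3 to compound 4 (0.67 log units; beyond the scatter), toward a stronger inhibitor. For compound 4 in this assay the estimate is 5000 nM, with a range from 1500 nM to 16000 nM.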

Compound 4, half-maximal inhibitory concentration: 452 nM
The estimate for compound 4 lay 11-fold (1.04 log units) above the measured number; the whole stated range lies above it.
By their numbers in this assay, from the lowest: compounds 2 and 4 (each within the scatter of the next); then compound 1; then compound 3.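

With the cap of compound 3 kept, quinolin-8-yl in place of (pyridin-4-yl)methyl on the amide-type nitrogen gives a 52-fold lower number from compound 3 to compound 4 (1.71 log units; beyond the scatter) in this assay. For the compounds shown here, the group on this nitrogen alone can therefore move the antiproliferative read-out by a large margin, which the earlier compounds, each differing from the others in more than one place, could not show. No supporting measurement bears on the reason for this step.

From the compounds shown here alone, the change swaps the ring system and also removes the methylene link, so the share of each remains open; a plain phenyl or a quinolin-8-ylmethyl group on the same nitrogen would separate the two. Going by these compounds, whether the same gain holds with the cap of compound 1 or compound 2 also remains open.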